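Aryloxyacetamide series: triazole to thiophene swap on the amide nitrogen

A few compounds are considered here, and "the series" means these few. Any claim that something is new, unique, unknown or untested is made for them only; others in the source may bear on it.

Measured so far:
compound 1 `CCN(Cc1c[nH]nn1)C(=O)COc1ccc(C)cc1` — 31100 nM
compound 2 `Cc1ccc(OCC(=O)N(Cc2cccs2)c2ncco2)cc1` — 0.3 nM
compound 3 `CCN(Cc1cccs1)C(=O)c1cc2cc(C)ccc2[nH]1` — 2010 nM

In an assay on HEK293 cells for agonist activity at transient receptor potential cation channel subfamily M member 8 (Homo sapiens), read by fluorescence and calcium flux, with a stated time of 15 min (on this read-out higher numbers stand for an effect only at larger amounts of compound and lower numbers for an effect already at smaller amounts), compound 1 gives the highest number of the three. Compound 3 lies nearest, and its step from compound 1 is beyond the scatter. Compound 2 lies furthest, far beyond the scatter. Among the compounds with values here, both compound 2 and compound 3 carry a thienylmethyl group on the amide-type nitrogen, whereas compound 1 carries a triazolylmethyl group there; the two lower numbers thus sit on the thiophene-bearing compounds, though each also differs from compound 1 elsewhere, so no single step between measured compounds is available.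

Compound 4 `CCN(Cc1ccsc1)C(=O)COc1ccc(C)cc1` differs from compound 1 in one place: thiophen-3-yl in place of 1H-1,2,3-triazol-4-yl on a saturated chain carbon bound to an amide-type nitrogen. The shared core of compound 1 is kept, the ethyl group on the nitrogen is kept, and only the heteroaryl ring on the methylene changes.

Compound 4 is expected to give a lower number than compound 1 in this assay, and the expected step is a 21-fold lower number from compound 1 to compound 4 (1.32 log units; beyond the scatter). This rests on compound 3 giving 2010 nM with a thienylmethyl group on the nitrogen, and on compound 2 giving 0.3 nM. Compound 4 is estimated at 1500 nM, with a range from 150 nM to 12000 nM.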

Compound 4, half-maximal effective concentration: 88 nM
Compound 4: middle estimate off by 17-fold (1.23 log units), on the high side; the whole stated range lies above it.
By their numbers in this assay, from the lowest: compound 2; then compound 4; then compound 3; then compound 1.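

In this assay, within the data shown here, replacing (1H-1,2,3-triazol-4-yl)methyl with (thiophen-3-yl)methyl gives a 350-fold lower number from compound 1 to compound 4 (2.55 log units; beyond the scatter), the first step that can be read at a single place. Among these compounds, the ethyl group and the shared core stay fixed, so this step ties a large change, well beyond the scatter, to the heteroaryl ring on the saturated chain carbon bound to an amide-type nitrogen alone; the earlier compounds could not isolate this position, since each also differed from compound 1 elsewhere. No measurement offered here bears on why the ring change has an effect of this size.

The ring swap keeps the heavy-atom count but changes the hetero atoms and removes the hydrogen-bond donor together, so the compounds shown cannot separate these differences from one another. As far as these compounds go, it remains open where a phenyl ring, a furan-3-yl ring or a 1-methyl-1H-1,2,3-triazol-4-yl ring at this position would fall, and whether the same swap gives a step of similar size on other amide substituents or cores.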